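Bromo for Methyl on the Ring of Compound 1

A few compounds are considered here, and "the series" means these few. Any claim that something is new, unique, unknown or untested is made for them only; others in the source may bear on it.

Compound 1 `Cc1ccc(NC(=O)N[C@H](C)c2ccccc2)cc1` is a urea with a methyl group on one aromatic ring. In an ADME assay on the whole organism with Oryza sativa as the target, tested at 1 uM (on this read-out higher numbers stand for a weaker effect at the one concentration tested and lower numbers for a stronger effect), compound 1 gives 98%. Compound 2 `Cc1ccc(NC(=O)N[C@@H](C)c2ccccc2)cc1` gives 99% in this assay, and compound 3 `C[C@H](NC(=O)Nc1ccccc1C(F)(F)F)c1ccccc1` gives 98%. Compound 1 stands level with compound 3 at the digits shown, the two of them together at the lowest numbers of the three, and its furthest companion is compound 2, at a distance that the usual scatter covers.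

Compound 4 `C[C@@H](NC(=O)Nc1ccc(Br)cc1)c1ccccc1` differs from compound 1 by bromo in place of methyl on an aromatic carbon. Among the compounds with values here, no measured step swaps one group for another; the single step, a number 1 percentage points higher from compound 1 to compound 2 (within the scatter), turns on the fact that compounds 1 and 2 differ only in the configuration as drawn and was within the scatter. With all three measured numbers sitting close together, the step expected in this assay, no change at the digits printed from compound 1 to compound 4 (within the scatter), is none beyond the scatter. Compound 4 is accordingly estimated at 98%, within a range from 88% to 100%.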

Compound 4, a percentage reported as activity, at one concentration (the size of the read-out at that concentration, not a potency): 95%
Estimate against measurement, compound 4: 3 percentage points above, within the range that was stated.
By their numbers in this assay, from the lowest: compounds 4, 1, 3 and 2 (each within the scatter of the next).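

At this place, on an aromatic carbon of a six-membered aromatic ring of carbon only and para to a large group, the swap of one group for another can now be read directly in this assay, and bromo in place of methyl gives a number 3 percentage points lower from compound 1 to compound 4 (within the scatter). The read-out therefore does not tell these two groups apart here, just as it did not tell apart the two drawn configurations of compounds 1 and 2. Nothing available accounts for this result, since the only supporting fact concerns configuration rather than this swap.

On these data alone, whether an amine or a carboxylic acid at this place would move the number beyond the scatter remains open. Also open, as far as these compounds go, is whether a longer chain there would do so, and in which direction.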